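A few compounds are considered here, and "the series" means these few. Any claim that something is new, unique, unknown or untested is made for them only; others in the source may bear on it.

Compounds measured so far in this series, with their values:

Compound 1 `O=C(CSc1nc(Nc2ccccc2)c2ccccc2n1)Nc1ccccc1F`: 12400 nM
Compound 2 `O=C(CSc1nc(Nc2ccccc2)c2ccccc2n1)Nc1ccccc1Cl`: 14600 nM
Compound 3 `C=CC(=O)Nc1cccc(NC(=O)CSc2nc(Nc3ccccc3)c3ccccc3n2)c1`: 8740 nM

In a functional assay on PC-3 cells (Homo sapiens) for inhibition, read by MTT assay, with a stated time of 72 h (a higher number here means a weaker inhibitor, a lower number a stronger inhibitor), compound 3 gives the lowest of the three numbers, but its separation from the others is small: a 1.4-fold lower number from compound 1 to compound 3 (0.15 log units; within the scatter) and a 1.7-fold lower number from compound 2 to compound 3 (0.22 log units; within the scatter), both within the scatter. Compound 4 `O=C(CSc1nc(Nc2ccccc2)c2ccccc2n1)Nc1ccc(Cl)cc1Cl` differs from compound 3 in one place: 2,4-dichlorophenyl in place of 3-((vinylcarbonyl)amino)phenyl on an amide-type nitrogen. Going by the values given here, three measured steps bear on this: the halogen swap a 1.2-fold higher number from compound 1 to compound 2 (0.07 log units; within the scatter), and the two aryl replacements on the amide-type nitrogen already named above. None moves beyond the scatter, so the shared core appears to carry the potency and the aryl group on the amide-type nitrogen changes little. For compound 4 a step of a 1.4-fold higher number from compound 3 to compound 4 (0.14 log units; within the scatter) is therefore expected, not beyond the scatter. The estimate for compound 4 in this assay is 12000 nM, with an expected range from 5000 nM to 30000 nM.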

Compound 4, half-maximal inhibitory concentration: 9110 nM
Compound 4: middle estimate off by 1.3-fold (0.12 log units), on the high side; the measured number falls inside the stated range.
By their numbers in this assay, from the lowest: compounds 3, 4, 1 and 2 (each within the scatter of the next).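

In this assay the 2,4-dichlorophenyl group on the amide-type nitrogen does not separate from 3-((vinylcarbonyl)amino)phenyl (a 1.0-fold higher number from compound 3 to compound 4 (0.02 log units; within the scatter)), although it has 0 hydrogen-bond donors and 0 hydrogen-bond acceptors. Chloro in place of hydrogen on an aromatic carbon (a 1.6-fold lower number from compound 2 to compound 4 (0.20 log units; within the scatter)) and 2,4-dichlorophenyl in place of 2-fluorophenyl (a 1.4-fold lower number from compound 1 to compound 4 (0.13 log units; within the scatter)) also stay within the scatter, so all the aryl changes seen at this position remain flat.

As far as these compounds go, whether an amine or a carboxylic acid on this aryl group, or a longer chain in its place, would give a step beyond the scatter remains open. No measurement on hand accounts for this flat response.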